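The source may report more compounds than this note shows. Statements on the series, on what has been measured and on what is new or still open speak of the compounds shown alone.

Compound 1 `CSc1nc(-c2ccc(Cl)cc2)nn1C(=O)N1CCCCC1`: 1.76 nM
Compound 2 `O=C(N1CCCCC1)n1nc(-c2ccc(Cl)cc2)nc1SCC1CC1`: 3.53 nM

In an assay (strain Wistar) for inhibition of Hormone-sensitive lipase (Rattus norvegicus), read by spectrophotometry (on this read-out lower numbers stand for stronger inhibition and higher numbers for weaker inhibition), compound 1 gives 1.76 nM, and compound 2 gives 3.53 nM; the pair lie within the scatter of each other, the step being a 2.0-fold higher number from compound 1 to compound 2 (0.30 log units; within the scatter). Compound 3 `CSc1nc(-c2ccc(Cl)cc2)nn1C(=O)N(C)c1ccccc1` is not yet measured. It differs from compound 1 by methyl(phenyl)amino in place of piperidin-1-yl on a carbonyl carbon. Within the data shown here, the single measured step concerns the chain on the sulfur, a different part of the shared core, so no measured step bears on this change. The expected step in this assay is therefore a 2.8-fold higher number from compound 1 to compound 3 (0.45 log units; beyond the scatter), a guarded guess. Compound 3 is expected at 5 nM, within 1 nM to 30 nM.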

Compound 3, half-maximal inhibitory concentration: 2.82 nM
Beside the measured number, compound 3's estimate is 1.8-fold (0.25 log units) above it; low and high end bracket the measured number.
By their numbers in this assay, from the lowest: compounds 1, 3 and 2 (each within the scatter of the next).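

In this assay the two groups on the carbonyl carbon cannot be told apart, with a 1.6-fold higher number from compound 1 to compound 3 (0.20 log units; within the scatter) for methyl(phenyl)amino in place of piperidin-1-yl. Among these compounds, this is the first view of that position: a six-membered aromatic ring of carbon only can enter there, in place of a six-membered non-aromatic ring, and the numbers stay within the scatter. No evidence is at hand that would explain this result. Still open, from the compounds shown here alone, is how a morpholin-4-yl group or a phenylamino group lacking the methyl would read at this carbonyl carbon.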